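The compounds below may be only part of what the source reports. "The series", "measured", "known", "first", "only" and "open" are said of these compounds alone.

Measured in a functional assay on K562 cells (Homo sapiens) for antiproliferative activity, read by MTT assay, with a stated time of 24 h; a higher number here means a weaker inhibitor, a lower number a stronger inhibitor:

Compound 1 `COc1ccc(C(=O)/C=C/c2ccc(Br)cc2)c2c1C=CC(C)(C)O2`: > 10000 nM
Compound 2 `COc1ccc(C(=O)/C=C/c2ccc(-c3ccccc3)cc2)c2c1C=CC(C)(C)O2`: > 10000 nM
Compound 3 `COc1ccc(C(=O)/C=C/c2ccco2)c2c1C=CC(C)(C)O2`: > 10000 nM

Each of these entries is a limit of the assay and not a number. Compound 3 stands at the limit of > 10000 nM in this assay, at which 3 of the 3 values shown sit, so its place on the scale is known only as a limit, and nothing sets it in order with the other two compounds.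

Compound 4 `COc1ccc(C(=O)/C=C/c2ccc(O)cc2)c2c1C=CC(C)(C)O2` keeps the shared core and differs from compound 3 in one group: 4-hydroxyphenyl in place of furan-2-yl on a double-bonded chain carbon bound to a double-bonded chain carbon. The change falls on a double-bonded chain carbon bound to a double-bonded chain carbon, and it brings in a hydrogen-bond donor.

The measured step at that same place is a step that the two limits leave unreadable from compound 1 to compound 3. The other measured step, on an aromatic carbon, is a step that the two limits leave unreadable from compound 1 to compound 2. Neither gives a size or a direction, so on this evidence no step beyond the scatter is expected in this assay, though a real gain cannot be ruled out.

The step expected is a number no higher from compound 3 to compound 4 (the limit leaves the size open), an estimate that rests on the limit of compound 3 alone. For compound 4 the estimated value is 10000 nM, with an expected range from 3000 nM to 30000 nM, and a report as a limit only is quite likely.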

Compound 4, half-maximal inhibitory concentration: > 10000 nM
Compound 4 gave a limit, no number (the forecaster's own chance of this, stated with the estimate: 60%); the middle value sits exactly at the limit.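

In this assay, compound 4 gives > 10000 nM, which is a limit and not a number. No step from compound 1, compound 2 or compound 3 to compound 4 can be read: the limit of > 10000 nM in this assay, at which 4 of the 4 values shown sit.

The compounds shown leave open how they rank in this assay and whether any of these group changes alters antiproliferative activity.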